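A few compounds are considered here, and "the series" means these few. Any claim that something is new, unique, unknown or untested is made for them only; others in the source may bear on it.

Three amides of the shared core carry numbers in a functional assay on HCT-116 cells (Homo sapiens) for cytotoxicity, read by MTT assay, with a stated time of 72 h; a lower number here means a stronger inhibitor, a higher number a weaker inhibitor. Compound 1 `CN1[C@@H]2c3[nH]c4ccccc4c3C[C@H]1[C@H](C#N)N1[C@@H](CNC(=O)c3cccc(C(F)(F)F)c3)c3[nH]c4ccccc4c3C[C@@H]21` gives 630 nM. Compound 2 `CCc1ccc(C(=O)NC[C@H]2c3[nH]c4ccccc4c3C[C@H]3[C@H]4c5[nH]c6ccccc6c5C[C@@H]([C@H](C#N)N23)N4C)cc1` gives 100 nM. Compound 3 `CN1[C@@H]2c3[nH]c4ccccc4c3C[C@H]1[C@H](C#N)N1[C@@H](CNC(=O)c3cccc4c3CCCC4)c3[nH]c4ccccc4c3C[C@@H]21` gives 4210 nM. Compound 1 therefore stands second highest of the three: a 6.3-fold lower number from compound 1 to compound 2 (0.80 log units; beyond the scatter), while a 6.7-fold higher number from compound 1 to compound 3 (0.82 log units; beyond the scatter). The widest gap in the set is a 42-fold higher number from compound 2 to compound 3 (1.62 log units; beyond the scatter).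

Compound 4 `CN1[C@@H]2c3[nH]c4ccccc4c3C[C@H]1[C@H](C#N)N1[C@@H](CNC(=O)/C=C/c3cccc(C(F)(F)F)c3)c3[nH]c4ccccc4c3C[C@@H]21` differs from compound 1 in one place: 2-(3-(trifluoromethyl)phenyl)ethenyl in place of 3-(trifluoromethyl)phenyl on a carbonyl carbon. Going by the values given here, no measured step bears directly on this change; all three measured steps exchange one aromatic group for another on the carbonyl carbon, and none adds a double bond outside aromatic rings. What they do show is that the number in this assay answers to what sits on that carbonyl carbon, the two steps leaving compound 1 being modest in opposite directions. With the 3-(trifluoromethyl)phenyl retained, the expectation is a step of modest size at most, direction open, or none beyond the scatter. The estimate for compound 4 is 500 nM, within 150 nM to 2000 nM, expected to mean a 1.3-fold lower number from compound 1 to compound 4 (0.10 log units; within the scatter).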

Compound 4, half-maximal inhibitory concentration: 610 nM
Compound 4: middle estimate off by 1.2-fold (0.09 log units), on the low side; low and high end bracket the measured number.
By their numbers in this assay, from the lowest: compound 2; then compounds 4 and 1 (each within the scatter of the next); then compound 3.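

In this assay, 2-(3-(trifluoromethyl)phenyl)ethenyl on the carbonyl carbon reads the same as 3-(trifluoromethyl)phenyl, with a 1.0-fold lower number from compound 1 to compound 4 (0.01 log units; within the scatter), whereas every earlier step at this position lay beyond the scatter. Going by these compounds alone, this is the first change here that retains the 3-(trifluoromethyl)phenyl and adds a double bond outside aromatic rings, and compound 4 keeps the place of compound 1 in the set, with a 6.9-fold lower number from compound 3 to compound 4 (0.84 log units; beyond the scatter) and a 6.1-fold higher number from compound 2 to compound 4 (0.79 log units; beyond the scatter). Nothing available bears on why the two groups read alike.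

As far as these compounds go, whether the double bond itself matters remains open, since a saturated ethylene link in the same place would be needed to tell. Also open, from the compounds shown here alone, is whether 2-(4-ethylphenyl)ethenyl would follow compound 2 rather than compound 4, and how an amine or a carboxylic acid on the aromatic ring would read.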